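Trimming the Ether: From Ethoxy to Free Hydroxy

The source may hold more compounds than are shown below. What is called first, only, known or untested is meant among the compounds shown, and "the series" means these compounds.

Compound 1, `C=CCOc1cccc(/C=N/n2c(-c3ccccc3)nc3ccccc3c2=O)c1`, gives 300 mg/kg.
Compound 2, `C=CCCOc1cccc(/C=N/n2c(-c3ccccc3)nc3ccccc3c2=O)c1`, gives 100 mg/kg.
Compound 3, `CCOc1cccc(/C=N/n2c(-c3ccccc3)nc3ccccc3c2=O)c1`, gives 100 mg/kg.

All three share one core and differ only in the chain hanging from the oxygen on the aromatic ring. In a functional assay on the whole organism (strain albino CF-1) with Mus musculus as the target, in the maximal electroshock model, with a stated time of 4 h (a lower number here means that less compound is needed, a higher number that more compound is needed for the effect), compound 3 stands level with compound 2 at the digits shown, and together these two hold the lowest numbers of the three; compound 1 is the furthest away.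

Compound 4, `O=c1c2ccccc2nc(-c2ccccc2)n1/N=C/c1cccc(O)c1`, carries the change (hydrogen in place of ethyl on an oxygen on an aromatic ring). The measured steps all concern what sits beyond the oxygen: a 3.0-fold lower number from compound 1 to compound 2 (0.48 log units; beyond the scatter) and a 3.0-fold lower number from compound 1 to compound 3 (0.48 log units; beyond the scatter) were modest, while no change at the digits printed from compound 2 to compound 3 (within the scatter) shows no change beyond the scatter. None of them removes the chain altogether, so they touch the change only indirectly; they suggest that shortening the chain did no harm, but compound 4 goes one step further than any measured compound.

The expected step is therefore no change at the digits printed from compound 3 to compound 4 (within the scatter), small or none beyond the scatter. Compound 4 is expected to give about 100 mg/kg, within a range from 50 mg/kg to 300 mg/kg.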

Compound 4, minimum effective dose: 100 mg/kg
Beside the measured number, compound 4's estimate shows no gap at the digits printed, and the stated range covers the measured number.
By their numbers in this assay, from the lowest: compounds 2, 3 and 4 (each within the scatter of the next); then compound 1.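

In this assay the ethyl group can be removed from the oxygen altogether, leaving a free hydroxy, with no change at the digits printed from compound 3 to compound 4 (within the scatter) and so the effect at this position does not depend on a chain on that oxygen. Setting the hydroxy against the longer but-3-en-1-yl chain gives the same picture, with no change at the digits printed from compound 2 to compound 4 (within the scatter) and the allyl chain is left as the one group that stands apart among these four, with a 3.0-fold lower number from compound 1 to compound 4 (0.48 log units; beyond the scatter) as the step from it to the free hydroxy. Nothing available here explains why hydroxy, ethoxy and but-3-en-1-yl sit level while allyl does not.

On these data alone, what would happen with an amine or a carboxylic acid in place of the hydroxy remains open. So does the effect of a chain longer than but-3-en-1-yl on this oxygen.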